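This account rests on a few compounds, and the source may have more. Where it says the series, first, only, none or still open, it means among the compounds named here.

Measured compounds:
compound 1, `COc1ccc(F)cc1CNCCCNc1ccnc2cc(Cc3ccc(C#N)cc3)ccc12`, 4200 nM;
compound 2, `COc1ccc(F)cc1CNCCCNc1ccnc2cc(Cc3cccc(C(F)(F)F)c3)ccc12`, 4200 nM;
compound 3, `N#Cc1ccc(Cc2ccc3c(NCCCNCc4ccco4)ccnc3c2)cc1`, 4200 nM.

Of the compounds shown here, three from this series have been measured in a physicochemical assay for solubility, with a stated time of 18 h, at pH 7.4; a lower number here means a less soluble compound, a higher number a more soluble compound. Compound 1 gives 4200 nM, compound 2 gives 4200 nM, and compound 3 gives 4200 nM, so the three sit level with one another in this assay.

Compound 2 differs from compound 1 in one place: 3-(trifluoromethyl)phenyl in place of 4-cyanophenyl on a saturated chain carbon bound to an aromatic carbon. That change made a step of no change at the digits printed from compound 1 to compound 2 (within the scatter). Compound 3 differs from compound 1 in a different place: furan-2-yl in place of 5-fluoro-2-methoxyphenyl on a saturated chain carbon bound to an amine nitrogen. That change made a step of no change at the digits printed from compound 1 to compound 3 (within the scatter).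

Compound 4, `FC(F)(F)c1cccc(Cc2ccc3c(NCCCNCc4ccco4)ccnc3c2)c1`, has not yet been measured in this assay. It differs from compound 3 as follows: 3-(trifluoromethyl)phenyl in place of 4-cyanophenyl on a saturated chain carbon bound to an aromatic carbon. This is the same change that carries compound 1 to compound 2, made on a second core; the place is the same in both cases, and the two cores differ by furan-2-yl in place of 5-fluoro-2-methoxyphenyl on a saturated chain carbon bound to an amine nitrogen.

Compound 3 stands level with compound 1, and in this assay compound 3 gives 4200 nM. Since this change made a step of no change at the digits printed from compound 1 to compound 2 (within the scatter) when it was made on the core of compound 1, the expected step for compound 4 in this assay is about no change at the digits printed from compound 3 to compound 4 (within the scatter). Compound 4 is therefore estimated at 4200 nM, with the expected range running from 2100 nM to 8400 nM.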

Compound 4, solubility: 4200 nM
Compound 4: middle estimate and measured number agree at the digits printed; low and high end bracket the measured number.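

In this assay, 3-(trifluoromethyl)phenyl in place of 4-cyanophenyl made a step of no change at the digits printed from compound 3 to compound 4 (within the scatter) on the second core, matching the step of no change at the digits printed from compound 1 to compound 2 (within the scatter) on the first, while furan-2-yl in place of 5-fluoro-2-methoxyphenyl, with the 3-(trifluoromethyl)phenyl group already present, made a step of no change at the digits printed from compound 2 to compound 4 (within the scatter). This shows that, across these two cores, the change carried over as a step within the scatter each time, and that the four compounds form a closed square with the same printed value at every corner; it does not show that the change would read the same on any other core, and a step of this size is a weak test of carrying over, since a larger step would say far more about whether a change keeps its size from one core to another. Nothing in the data shown bears on why these four compounds read alike.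

The compounds shown leave open whether a group bearing a carboxylic acid or an amine, in place of 4-cyanophenyl or 3-(trifluoromethyl)phenyl, would move the reading in this assay. They also leave open whether the step seen here would hold with a longer chain in the shared core.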